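This account rests on a few compounds, and the source may have more. Where it says the series, first, only, none or still open, it means among the compounds named here.

Measured so far in a functional assay, with a stated time of 30 min, in the absence of a further agent; a lower number here means a stronger inhibitor, a higher number a weaker inhibitor:
compound 1 `O=C(Nc1nnc(-c2cccc(O)c2O)s1)c1ccc(Cl)cc1` gives 30200 nM
compound 2 `O=C(COc1ccccc1)Nc1nnc(-c2cccc(O)c2O)s1` gives 16600 nM
compound 3 `O=C(Nc1nnc(-c2cccc(O)c2O)s1)c1ccccc1` gives 22300 nM

Compound 3 at 22300 nM lies within the scatter of both other compounds. Compound 4 `CC(=O)Nc1nnc(-c2cccc(O)c2O)s1` keeps the shared core but has methyl in place of phenyl on a carbonyl carbon. Two measured steps changed the group on that carbonyl carbon (a 1.8-fold lower number from compound 1 to compound 2 (0.26 log units; within the scatter) and a 1.3-fold higher number from compound 2 to compound 3 (0.13 log units; within the scatter)). Both stayed within the scatter, as did the swap of chloro for hydrogen (a 1.4-fold lower number from compound 1 to compound 3 (0.13 log units; within the scatter)). As far as these compounds go, every measured compound still has a ring in that group, so methyl remains untested. In this assay no step beyond the scatter is expected, and the expected step is small (a 1.1-fold higher number from compound 3 to compound 4 (0.05 log units; within the scatter)). The estimated value for compound 4 is 25000 nM (expected range 11000 nM to 60000 nM).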

Compound 4, half-maximal inhibitory concentration: 111000 nM
For compound 4 the middle estimate is 4.4-fold (0.65 log units) below the measured one; the whole stated range lies below it.
By their numbers in this assay, from the lowest: compounds 2, 3 and 1 (each within the scatter of the next); then compound 4.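

Among the results so far (this assay), taking the ring out of the group on the carbonyl carbon is the first change that goes beyond the scatter: methyl in place of phenyl gives a weaker inhibitor (a 5.0-fold higher number from compound 3 to compound 4 (0.70 log units; beyond the scatter)), and the steps from the other two compounds agree (a 6.7-fold higher number from compound 2 to compound 4 (0.83 log units; beyond the scatter)) (a 3.7-fold higher number from compound 1 to compound 4 (0.57 log units; beyond the scatter)). Phenyl, 4-chlorophenyl and phenoxymethyl stayed within the scatter of one another, so compound 4 alone stands apart. Nothing available gives a reason for this. Still open, as far as these compounds go, is whether the ring itself counts or simply more carbon atoms: a longer chain such as butyl, or a cyclohexyl ring, on that carbonyl carbon would separate the two.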